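The compounds below may be only part of what the source reports. "The series", "measured", "known", "first", "only" and "open" are said of these compounds alone.

Three compounds of a shared core were compared in an assay on CHO cells for displacement of a labelled ligand from prostaglandin D2 receptor 2 (Homo sapiens), read by scintillation counting; on this read-out lower numbers stand for stronger inhibition and higher numbers for weaker inhibition. Compound 1, of structure `CCS(=O)(=O)c1ccc(C)c(C#Cc2cc(Cl)ccc2OCC(=O)O)c1`, gives 8.6 nM in this assay. Compound 2, of structure `CS(=O)(=O)Cc1cccc(C#Cc2cc(Cl)ccc2OCC(=O)O)c1`, gives 48 nM in this assay, and compound 3, of structure `CCCS(=O)(=O)c1cccc(C#Cc2c(OCC(=O)O)cccc2-c2ccsc2)c1`, gives 18 nM in this assay. Compound 1 thus stands with the lowest number of the three, and both its companions lie beyond the usual scatter of it, so within this small set it is the strongest inhibitor.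

Compound 4, of structure `CCN(CC)S(=O)(=O)c1ccc(C)c(C#Cc2cc(Cl)ccc2OCC(=O)O)c1`, has not yet been measured in this assay. It differs from compound 1 in one place: diethylamino in place of ethyl on a sulfonyl sulfur. Among the compounds with values here, no pair of measured compounds shows a change of this kind, so nothing in the data tells directly how large a step it brings.

The account therefore rests on the position of compound 1 alone. A modest change in this assay is expected, with the number for compound 4 most likely moving no further than the scatter allows, perhaps a little upward, so that the step of a 1.4-fold higher number from compound 1 to compound 4 (0.14 log units; within the scatter) is expected to be small. Compound 4 is estimated at 12 nM in this assay, within a range from 4 nM to 40 nM.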

Compound 4, inhibition constant: 3.4 nM
For compound 4 the middle estimate is 3.5-fold (0.55 log units) above the measured one; the whole stated range lies above it.
By their numbers in this assay, from the lowest: compound 4; then compound 1; then compound 3; then compound 2.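

In this assay, the sulfonyl sulfur of the core of compound 1 accepts a larger group than ethyl: diethylamino, with 5 heavy atoms in place of 2, brings a 2.5-fold lower number from compound 1 to compound 4 (0.40 log units; beyond the scatter), a modest step but one beyond the usual scatter. Within the data shown here, the three earlier compounds offered no pair differing in one place, so this is the first single change that can be read in the set, and the change from ethylsulfonyl to diethylsulfamoyl on this core goes toward stronger inhibition. Nothing measured here explains why the step runs in this direction.

This one step does not separate the contribution of the nitrogen on the sulfonyl sulfur from that of the two ethyl chains it carries; ethylamino, dimethylamino or the longer dipropylamino in the same place would bear on that question. It also leaves open whether diethylamino in place of the chain on the sulfonyl sulfur of compound 3 would bring a step of like direction and size on that different core.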